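The compounds below may be only part of what the source reports. "The series", "measured", "known", "first", "only" and "open" are said of these compounds alone.

In a functional assay on HeLa cells (Homo sapiens) for antiproliferative activity, read by MTT assay, with a stated time of 48 h (on this read-out higher numbers stand for weaker inhibition and lower numbers for stronger inhibition), the measured compounds are:

Compound 1 `CSc1nc(-c2ccc(C)cc2)nc2ccc(Cl)cc12` gives 14.7 ug/mL
Compound 2 `C=CCSc1nc(-c2ccc(C)cc2)nc2ccc(Cl)cc12` gives 9.66 ug/mL

Among the compounds with values here, compound 2 stands within the scatter of compound 1, the only other measured compound. Compound 3 `Cc1ccc(-c2nc(SCCO)c3cc(Cl)ccc3n2)cc1` is not yet measured and differs from compound 2 as follows: hydroxymethyl in place of vinyl on a saturated chain carbon bound to a sulfur. This places hydroxymethyl in place of vinyl on a saturated chain carbon bound to a sulfur. Within the data shown here, the one measured step at this carbon is a 1.5-fold lower number from compound 1 to compound 2 (0.18 log units; within the scatter). Among the measured compounds shown here, no measured compound carries hydroxymethyl, so no shift beyond the scatter is expected in this assay. The estimated step is a 1.2-fold higher number from compound 2 to compound 3 (0.09 log units; within the scatter). Compound 3 is expected at 12 ug/mL, with an estimated range of 5 ug/mL to 30 ug/mL.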

Compound 3, half-maximal inhibitory concentration: 9.25 ug/mL
Estimate against measurement, compound 3: 1.3-fold (0.11 log units) above; measured number inside the range.
By their numbers in this assay, from the lowest: compounds 3, 2 and 1 (each within the scatter of the next).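

In this assay, replacing vinyl with hydroxymethyl on the saturated chain carbon bound to a sulfur gives a 1.0-fold lower number from compound 2 to compound 3 (0.02 log units; within the scatter). Replacing hydrogen there with hydroxymethyl gives a 1.6-fold lower number from compound 1 to compound 3 (0.20 log units; within the scatter). Thus this carbon has now carried hydrogen, vinyl and hydroxymethyl, including a group with a hydrogen-bond donor and acceptor, without any step leaving the scatter. No supporting evidence bears on why these values stay so close. From the compounds shown here alone, whether an amine, a carboxylic acid or a longer chain at this carbon would shift the number beyond the scatter remains open.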